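Chloro for fluoro on the fused ring, two cores compared

The source may hold more compounds than are shown below. What is called first, only, known or untested is meant among the compounds shown, and "the series" means these compounds.

Compound 1 `Cc1ccc(-c2cc(C(=O)Nc3cccnc3)c3cc(Cl)ccc3n2)cc1` and compound 2 `Cc1ccc(-c2cc(C(=O)Nc3cccnc3)c3cc(F)ccc3n2)cc1` share one core and differ only in the halogen on the fused ring. In an ADME assay on MRC5 cells (Homo sapiens) for antiproliferative activity, read by fluorescence and resazurin assay, with a stated time of 68 h (a lower number here means that less compound is needed, a higher number that more compound is needed for the effect), compound 1 gives 21000 nM, and in this assay compound 2 gives 50000 nM. The change between them is chloro in place of fluoro on an aromatic carbon, and it moves the read-out by a 2.4-fold lower number from compound 2 to compound 1 (0.38 log units; beyond the scatter).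

Compound 3 `O=C(NCCN1CCCC1)c1cc(NCCC2CCOCC2)nc2ccc(F)cc12` carries a different core. In this assay compound 3 reaches only a limit, > 50000 nM, so no number stands for it. How the core of compound 3 differs from the core of compound 2 is not broken down here.

Compound 4 `O=C(NCCN1CCCC1)c1cc(NCCC2CCOCC2)nc2ccc(Cl)cc12` is the unmeasured partner of compound 3, obtained by chloro in place of fluoro on an aromatic carbon. This is the same change as from compound 2 to compound 1, at a place described in the same words. Whatever compound 4 does in this assay can only be read against the limit of compound 3, since the limit of > 50000 nM in this assay, at which 1 of the 3 values shown sits, is all that is known there; the earlier step of a 2.4-fold lower number from compound 2 to compound 1 (0.38 log units; beyond the scatter) suggests a modest gain at most, which may or may not bring compound 4 under that limit. The step expected from compound 3 to compound 4 is an at least 1.1-fold lower number from compound 3 to compound 4 (0.04 log units; that floor lies within the scatter), set beside a 2.4-fold lower number from compound 2 to compound 1 (0.38 log units; beyond the scatter). It rests on the limit of compound 3, > 50000 nM. For compound 4 the expected value in this assay is 45000 nM, with a range from 15000 nM to 50000 nM.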

Compound 4, half-maximal effective concentration: 31000 nM
Estimate against measurement, compound 4: 1.5-fold (0.16 log units) above; low and high end bracket the measured number.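

On the core of compound 3, chloro in place of fluoro on an aromatic carbon gives an at least 1.6-fold lower number from compound 3 to compound 4 (0.20 log units; that floor lies within the scatter) in this assay, which points the same way as the step on the core of compound 1, but its floor alone does not clear the scatter. This shows that the direction seen on the first core is not contradicted on the second, and it does not show that the change has the same size on both cores: the same change on two cores in this assay, a 2.4-fold lower number (0.38 log units; beyond the scatter) from compound 2 to compound 1 and an at least 1.6-fold lower number (0.20 log units; that floor lies within the scatter) from compound 3 to compound 4; the limit leaves it open whether they differ

Compound 3 is held only by a limit of the assay and not by a number, which leaves the true size of the step on this core unknown: the limit of > 50000 nM in this assay, at which 1 of the 4 values shown sits.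

From the compounds shown here alone, only fluoro and chloro appear at this place on the fused ring, and whether bromo, methyl or a nitrile there would continue the same direction remains open. Also open, going by these compounds, is whether the step would hold on a third core, or with an amine or a longer chain in place of the side groups carried by these compounds.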